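The source may hold more compounds than are shown below. What is called first, only, known or untested is meant among the compounds shown, and "the series" means these compounds.

Within the data shown here, compound 1 `CC1(C)[C@@H]2CC[C@@]1(CS(=O)(=O)N1CCN(c3ncccc3C(F)(F)F)CC1)C(=O)C2` is one of three compounds measured in a functional assay on CHO-K1 cells for antagonist activity at C-X-C chemokine receptor type 3 (Homo sapiens), read by FLIPR and calcium flux; on this read-out lower numbers stand for stronger inhibition and higher numbers for weaker inhibition. For compound 1 the reading is only a limit of the assay, > 31600 nM. Compound 3 `CC1(C)[C@@H]2CC[C@@]1(CS(=O)(=O)N1C[C@@H]3C[C@H]1CN3c1ccc(C(F)(F)F)cn1)C(=O)C2` likewise returns only a limit, > 31600 nM. Compound 2 `CC1CN(c2ccc(C(F)(F)F)cn2)CCN1S(=O)(=O)C[C@]12CC[C@H](CC1=O)C2(C)C` gives 631 nM. Compound 1 thus sits at the limit of > 31600 nM in this assay, at which 2 of the 3 values shown sit, and no number separates it from compound 3. Compound 4 `CC1(C)[C@@H]2CC[C@@]1(CS(=O)(=O)N1CCN(c3ccccn3)CC1)C(=O)C2` differs from compound 1 by hydrogen in place of trifluoromethyl on an aromatic carbon. Among the measured compounds shown here, no measured pair shows this change, so no step size can be drawn from the data. Because compound 1 sits at the limit of > 31600 nM in this assay, at which 2 of the 3 values shown sit, compound 4 is expected to stay at or near that limit, an expected step that the limit leaves unreadable from compound 1 to compound 4 of none beyond the scatter. Compound 4 is therefore estimated at 40000 nM, between 10000 nM and 120000 nM.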

Compound 4, half-maximal inhibitory concentration: > 31600 nM
Compound 4 ended at the assay's limit (the forecaster's own chance of this, stated with the estimate: 80%); the middle value does not contradict the limit.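

In this assay, compound 1 and compound 4 both return only a limit of the assay, so no step can be read between them. The compounds shown leave open what hydrogen in place of trifluoromethyl does to inhibition.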